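Nitrogen substituent series: returning from fluorobenzyl to a small alkyl

The compounds below may be only part of what the source reports. "The series", "measured", "known", "first", "only" and "open" are said of these compounds alone.

Among the compounds with values here, compound 3 `CC(C)c1onc(-c2c(Cl)cccc2Cl)c1COc1ccc(-c2nc3ccc(C(=O)O)cc3n2Cc2ccc(F)cc2)cc1` has the lowest number of the three measured so far in an assay on HEK-293T cells for antagonist activity at vitamin D3 receptor (Homo sapiens), read by a luciferase reporter, with a stated time of 24 h; a lower number here means a stronger inhibitor, a higher number a weaker inhibitor; in this assay compound 3 gives 1140 nM. Compound 1 `CC(C)c1onc(-c2c(Cl)cccc2Cl)c1COc1ccc(-c2nc3ccc(C(=O)O)cc3n2C)cc1` gives 7150 nM, and compound 2 `CCC(CC)n1c(-c2ccc(OCc3c(-c4c(Cl)cccc4Cl)noc3C(C)C)cc2)nc2ccc(C(=O)O)cc21` gives 5690 nM. The step of a 1.3-fold lower number from compound 1 to compound 2 (0.10 log units; within the scatter) stays within the scatter, whereas the steps of a 6.3-fold lower number from compound 1 to compound 3 (0.80 log units; beyond the scatter) and a 5.0-fold lower number from compound 2 to compound 3 (0.70 log units; beyond the scatter) both go beyond it. Compound 4 `CCn1c(-c2ccc(OCc3c(-c4c(Cl)cccc4Cl)noc3C(C)C)cc2)nc2ccc(C(=O)O)cc21` is compound 3 with methyl in place of 4-fluorophenyl on a saturated chain carbon bound to an aromatic nitrogen. This reverses the two larger measured steps, which bear on it directly, since compound 4 again carries a small alkyl on the nitrogen as compound 1 and compound 2 do. A rise back toward their numbers is therefore expected, about a 5.7-fold higher number from compound 3 to compound 4 (0.76 log units; beyond the scatter). Compound 4 is estimated at 6500 nM, with a range from 3000 nM to 14000 nM.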

Compound 4, half-maximal inhibitory concentration: 5760 nM
For compound 4 the middle estimate is 1.1-fold (0.05 log units) above the measured one; the range from low to high includes it.
By their numbers in this assay, from the lowest: compound 3; then compounds 2, 4 and 1 (each within the scatter of the next).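

In this assay, ethyl on the aromatic nitrogen is not told apart from pentan-3-yl (a 1.0-fold higher number from compound 2 to compound 4 (0.01 log units; within the scatter)) or from methyl (a 1.2-fold lower number from compound 1 to compound 4 (0.09 log units; within the scatter)). The change from 4-fluorobenzyl to ethyl gives (a 5.1-fold higher number from compound 3 to compound 4 (0.70 log units; beyond the scatter)), so three alkyl groups now stand apart from 4-fluorobenzyl, with no trend across them from methyl through ethyl to pentan-3-yl. No measurement here explains this difference.

Still open, as far as these compounds go, is whether the ring or its fluorine carries the difference, as unsubstituted benzyl would test. A longer phenethyl chain on the same nitrogen also remains untested in the compounds shown.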